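Halogen placement on the benzyl thiourea and channel binding

The source may hold more compounds than are shown below. What is called first, only, known or untested is meant among the compounds shown, and "the series" means these compounds.

Compound 2 `COc1cc(CNC(=S)NCC(COC(=O)C(C)(C)C)Cc2ccc(C)c(C)c2)cc(I)c1O`: 232 nM
Compound 1 `COc1cc(CNC(=S)NCC(COC(=O)C(C)(C)C)Cc2ccc(C)c(C)c2)cc(Br)c1O`: 33.1 nM

Among the measured compounds shown here, compound 2 holds the higher of the two numbers so far in an assay on CHO cells for displacement of a labelled ligand from transient receptor potential cation channel subfamily V member 1 (Rattus norvegicus); a higher number here means a weaker inhibitor, a lower number a stronger inhibitor; its nearest neighbour, compound 1, sits a step away that reads a 7.0-fold higher number from compound 1 to compound 2 (0.85 log units; beyond the scatter) when taken from compound 1 to compound 2. The unmeasured compound 3 `COc1cc(CNC(=S)NCC(COC(=O)C(C)(C)C)Cc2ccc(C)c(C)c2)c(Br)cc1O` differs from compound 2 in one place: 2-bromo-4-hydroxy-5-methoxyphenyl in place of 4-hydroxy-3-iodo-5-methoxyphenyl on a saturated chain carbon bound to an amide-type nitrogen. For the measured compounds named here, only one measured step touches this change, and it bears on the halogen alone: iodo in place of bromo on an aromatic carbon raised the number by a 7.0-fold higher number from compound 1 to compound 2 (0.85 log units; beyond the scatter). Going by the values given here, compound 3 returns to bromo, which by that step argues for a lower number than compound 2, but it also carries the bromo at a different ring position, for which no measured pair exists. The expected outcome in this assay is therefore a modest move downward, with wide uncertainty, expressed as a 2.6-fold lower number from compound 2 to compound 3 (0.41 log units; beyond the scatter). Compound 3 is estimated at 90 nM, within a range of 20 nM to 400 nM.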

Compound 3, inhibition constant: 19.9 nM
Beside the measured number, compound 3's estimate is 4.5-fold (0.66 log units) above it; the measured number lies below the stated range.
By their numbers in this assay, from the lowest: compounds 3 and 1 (each within the scatter of the next); then compound 2.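

In this assay, the two bromo arrangements, 3-bromo-4-hydroxy-5-methoxyphenyl and 2-bromo-4-hydroxy-5-methoxyphenyl, are separated by a 1.7-fold lower number from compound 1 to compound 3 (0.22 log units; within the scatter), so this assay does not tell them apart and the bromo need not hold one ring position for the number to stay in this range. Compound 2, the only iodo compound among the three, therefore stands apart from both bromo compounds, with a 12-fold lower number from compound 2 to compound 3 (1.07 log units; beyond the scatter); among these compounds, the halogen rather than the bromo's ring position marks the large step. Nothing available here explains why iodo and bromo differ in this way or why the two bromo compounds cannot be separated.

The compounds shown leave open whether an iodo group in the place that the bromo holds in 2-bromo-4-hydroxy-5-methoxyphenyl would follow compound 2 or the bromo compounds. They also leave open how a chloro or fluoro group, or plain hydrogen, would read in either ring position, and whether the same tolerance would hold if a carboxylic acid replaced the pivalate ester on the shared core.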